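This account rests on a few compounds, and the source may have more. Where it says the series, first, only, none or still open, it means among the compounds named here.

Three compounds share one core and differ only in the aromatic ring on the chain. Compound 1 `Cc1ccc(/C=C/C(=O)c2ccccc2NC(=O)NS(=O)(=O)c2ccc(C)cc2)cc1` in an ADME assay on the whole organism for cytotoxicity, with Artemia salina as the target, with a stated time of 24 h (a higher number here means that more compound is needed for the effect, a lower number that less compound is needed), gives 15.3 ug/mL. Compound 2 `COc1ccc(/C=C/C(=O)c2ccccc2NC(=O)NS(=O)(=O)c2ccc(C)cc2)c(OC)c1` in this assay gives 16 ug/mL, and compound 3 `COc1cc(/C=C/C(=O)c2ccccc2NC(=O)NS(=O)(=O)c2ccc(C)cc2)ccc1O` in this assay gives 17.8 ug/mL. The three numbers sit close together: a 1.0-fold higher number from compound 1 to compound 2 (0.02 log units; within the scatter), a 1.2-fold higher number from compound 1 to compound 3 (0.07 log units; within the scatter) and a 1.1-fold higher number from compound 2 to compound 3 (0.05 log units; within the scatter) are all within the scatter, so compound 3 stands among them without a separating gap.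

Compound 4 `Cc1ccc(S(=O)(=O)NC(=O)Nc2ccccc2C(=O)/C=C/c2ccc(Cl)cc2Cl)cc1` is not yet measured. Relative to compound 3 the change is 2,4-dichlorophenyl in place of 4-hydroxy-3-methoxyphenyl on a double-bonded chain carbon bound to a double-bonded chain carbon. Every step seen so far swaps this same aromatic ring, and none of those swaps moved the number beyond the scatter. On that basis, the step from compound 3 to compound 4 is expected to be a 1.0-fold lower number from compound 3 to compound 4 (0.02 log units; within the scatter), that is, nothing beyond the scatter. Compound 4 is therefore expected to give about 17 ug/mL, with a plausible range from 9 ug/mL to 34 ug/mL.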

Compound 4, concentration for half-maximal effect: 8.34 ug/mL
Beside the measured number, compound 4's estimate is 2.0-fold (0.31 log units) above it, and the stated range ends above it.
By their numbers in this assay, from the lowest: compounds 4, 1, 2 and 3 (each within the scatter of the next, the first and the last beyond it).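

Swapping the ring at this position, on a double-bonded chain carbon bound to a double-bonded chain carbon, can move the number in this assay beyond the scatter: 2,4-dichlorophenyl in place of 4-hydroxy-3-methoxyphenyl gives a 2.1-fold lower number from compound 3 to compound 4 (0.33 log units; beyond the scatter) and is the only step of this size in the set. The same group stays within the scatter against the other two rings, with a 1.9-fold lower number from compound 2 to compound 4 (0.28 log units; within the scatter) and a 1.8-fold lower number from compound 1 to compound 4 (0.26 log units; within the scatter), so compound 4 separates clearly from compound 3 alone. Nothing available here accounts for that single step.

As far as these compounds go, it remains open whether both chlorine atoms are needed, which 4-chlorophenyl at this position would test. A ring carrying an amine or a carboxylic acid might also shift the number further, or in the opposite direction.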